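This account rests on a few compounds, and the source may have more. Where it says the series, first, only, none or still open, it means among the compounds named here.

Compound 2 `O=[N+]([O-])c1ccc(-c2cn(Cc3ccccc3)nn2)cc1` is the starting point of this step. Among the measured compounds shown here, in a functional assay on B16 cells (Mus musculus) for cytotoxicity, read by MTT assay, with a stated time of 48 h (a lower number here means a stronger inhibitor, a higher number a weaker inhibitor), compound 2 gives 5120 nM, the lower of the two numbers measured so far. For the measured compounds named here, the only other measured compound, compound 1 `CC1(C)OCC(Cn2cc(-c3ccc(C(F)(F)F)cc3)nn2)O1`, gives 13500 nM in this assay, and the gap between the two lies beyond the usual scatter of repeated measurements. Compound 3 `CC1(C)OCC(Cn2cc(-c3ccc([N+](=O)[O-])cc3)nn2)O1` has not yet been measured. It differs from compound 2 in one place: 2,2-dimethyl-1,3-dioxolan-4-yl in place of phenyl on a saturated chain carbon bound to an aromatic nitrogen. Going by the values given here, no pair of measured compounds shows this change on its own, so its effect is not known from the data. Compound 1, which gives 13500 nM, carries the same 2,2-dimethyl-1,3-dioxolan-4-yl group that enters in compound 3, and that is the only hint available. A weakening step a 2.0-fold higher number from compound 2 to compound 3 (0.29 log units; within the scatter) is therefore expected, of moderate size. Compound 3 is estimated at 10000 nM, within a range from 3000 nM to 35000 nM.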

Compound 3, half-maximal inhibitory concentration: > 100000 nM
Compound 3: no number, only a limit (the forecaster's own chance of this, stated with the estimate: 10%); middle value at least 10-fold (1.00 log units) from the limit.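

In this assay, compound 3 has no exact number, only a limit of the assay: the limit of > 100000 nM in this assay, at which 1 of the 3 values shown sits.

Even so, the first clean view of this position is clear: 2,2-dimethyl-1,3-dioxolan-4-yl in place of phenyl on the saturated chain carbon gives an at least 19-fold higher number from compound 2 to compound 3 (1.29 log units; beyond the scatter), so the nitro series loses nearly all measurable cytotoxicity with this change. The group on the aromatic carbon also counts, since nitro in place of trifluoromethyl, with the dioxolane group kept, gives an at least 7.4-fold higher number from compound 1 to compound 3 (0.86 log units; beyond the scatter), something compound 1 alone could not show.

Going by these compounds, with only a limit for compound 3, the true size of both steps stays open, and so does whether phenyl would also outperform the dioxolane group with trifluoromethyl on the aromatic carbon. On these data alone, it is also open how an open-chain diol or a simple ethyl chain would behave at this position.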